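A few compounds are considered here, and "the series" means these few. Any claim that something is new, unique, unknown or untested is made for them only; others in the source may bear on it.

Measured compounds in a functional assay on MCF7 cells (Homo sapiens) for antiproliferative activity, read by MTT assay; on this read-out lower numbers stand for stronger inhibition and higher numbers for weaker inhibition:
compound 1, `COc1ccc([C@@H]2[C@@H](C(=O)c3ccsc3)C(=O)N2c2cc(OC)c(OC)c(OC)c2)cc1`, 470 nM
compound 2, `COc1ccc([C@@H]2[C@@H](c3cccs3)C(=O)N2c2cc(OC)c(OC)c(OC)c2)cc1N`, 42 nM
compound 3, `COc1ccc([C@@H]2C(Cc3cccs3)C(=O)N2c2cc(OC)c(OC)c(OC)c2)cc1`, 1640 nM

Among these three numbers compound 1 stands second highest. Its nearest neighbour is compound 3, whose number is higher by a gap beyond the usual scatter, while compound 2 lies furthest away, with a number lower by a gap that is also well beyond the scatter. Compound 1 is thus neither the strongest nor the weakest of the measured set.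

The new compound, compound 4, `COc1ccc([C@@H]2[C@@H](C(O)c3ccc(C)s3)C(=O)N2c2cc(OC)c(OC)c(OC)c2)cc1`, is built from compound 1 by a single change on the shared core: hydroxy(5-methylthiophen-2-yl)methyl in place of (thiophen-3-yl)carbonyl on a saturated ring carbon. Among the measured compounds shown here, no step between two measured compounds mirrors this change, so the direction has to be judged from the compounds at hand. Compound 3, in which the ring carbon carries a thiophene through a saturated link rather than a carbonyl, gives 1640 nM in this assay, a weaker number than compound 1. On that basis compound 4 is expected to fall somewhat short of compound 1, with a step of a 1.9-fold higher number from compound 1 to compound 4 (0.28 log units; within the scatter) expected in the direction of a higher number, of modest size. The estimate for compound 4 in this assay is 900 nM, with a range from 300 nM to 2700 nM.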

Compound 4, half-maximal inhibitory concentration: 1260 nM
Beside the measured number, compound 4's estimate is 1.4-fold (0.15 log units) below it; the measured number falls inside the stated range.
By their numbers in this assay, from the lowest: compound 2; then compound 1; then compounds 4 and 3 (each within the scatter of the next).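

Among the compounds shown here, exchanging (thiophen-3-yl)carbonyl for hydroxy(5-methylthiophen-2-yl)methyl on the saturated ring carbon of the shared core gives a 2.7-fold higher number from compound 1 to compound 4 (0.43 log units; beyond the scatter) in this assay, the first step that can be read between two compounds differing in one place only. It shows that the number at this position responds to the nature of the group, though the step is modest in size. The entering group carries a hydrogen-bond donor that the leaving group lacks, a methyl on the thiophene and a different attachment to that ring, and no information is available on why the number moves.

The compounds shown leave open how the step divides among these features, since the hydroxy group, the methyl group and the thiophene attachment all change together. They also leave open how this position would respond to an amine, a carboxylic acid or a longer chain in place of the thiophene-bearing groups.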